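This account rests on a few compounds, and the source may have more. Where it says the series, first, only, none or still open, it means among the compounds named here.

In a functional assay on NCI-H1975 cells (Homo sapiens) for cytotoxicity, read by MTT assay, with a stated time of 72 h (a higher number here means a weaker inhibitor, a lower number a stronger inhibitor), compound 2 `CCN1C/C(=C\c2cc(OC)c(OC)c(OC)c2)C(=O)/C(=C/c2cc(OC)c(OC)c(OC)c2)C1` gives 6500 nM as its reading. Compound 3 `COc1ccc(/C=C2\CN(C)C/C(=C\c3ccc(OC)c(OC)c3)C2=O)cc1OC` gives 6600 nM in the same test, within the scatter of compound 2. Compound 1 `COc1cc(/C=C2\CN(C)C/C(=C\c3cc(OC)c(OC)c(OC)c3)C2=O)cc(OC)c1OC` gives 1000 nM as a clearly lower number. The next structure, compound 4 `COc1cc(/C=C2\CN(C(=O)C(C)C)C/C(=C\c3cc(OC)c(OC)c(OC)c3)C2=O)cc(OC)c1OC`, has isopropylcarbonyl in place of ethyl on an amine nitrogen in a ring, a difference counted as isopropylcarbonyl in place of ethyl on an amine nitrogen in a ring in full.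

For the measured compounds named here, only one measured step bears on this position, namely a 6.5-fold higher number from compound 1 to compound 2 (0.81 log units; beyond the scatter) at that same nitrogen, a modest move beyond the scatter. Going by the values given here, no measured compound carries isopropylcarbonyl, so the data do not settle the direction. Among the compounds with values here, the expectation rests on compound 1 at 1000 nM showing that the number in this assay can lie well under that of compound 2 when only this group differs. A modest drop is therefore expected, estimated as a 3.6-fold lower number from compound 2 to compound 4 (0.56 log units; beyond the scatter) in size and within reach of the earlier step. Compound 4 is estimated at 1800 nM with an expected range from 450 nM to 7000 nM overall.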

Compound 4, half-maximal inhibitory concentration: 1900 nM
Compound 4: middle estimate off by 1.1-fold (0.02 log units), on the low side; the range from low to high includes it.
By their numbers in this assay, from the lowest: compounds 1 and 4 (each within the scatter of the next); then compounds 2 and 3 (each within the scatter of the next).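

In this assay, the change from ethyl to isopropylcarbonyl on the amine nitrogen in the ring gives a 3.4-fold lower number from compound 2 to compound 4 (0.53 log units; beyond the scatter), which shows that this position can take a larger group carrying a carbonyl and a hydrogen-bond acceptor without the number rising. Set against the methyl group, isopropylcarbonyl gives a 1.9-fold higher number from compound 1 to compound 4 (0.28 log units; within the scatter), so these two groups cannot be told apart here, and among the three groups at this nitrogen only ethyl stands clear of both. Nothing available explains why the reading shifts with these groups.

The compounds shown leave open how a hydrogen, a longer chain such as propyl, or a benzoyl group would read at this nitrogen. They also leave open whether isopropylcarbonyl would give a similar step on the core of compound 3.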